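A few compounds are considered here, and "the series" means these few. Any claim that something is new, unique, unknown or untested is made for them only; others in the source may bear on it.

Compound 1 `COc1cc(Cl)c(Nc2nc(Cl)cn([C@@H](COCCF)C3CC3)c2=O)c(Cl)c1`: 0.6 nM
Compound 2 `COc1cc(Cl)c(Nc2nc(Br)cn([C@@H](COCCF)C3CC3)c2=O)c(Cl)c1`: 0.46 nM

Both numbers come from an assay on frontal cortex for displacement of a labelled ligand from corticotropin-releasing factor receptor 1 (Rattus norvegicus), with a stated time of 2 h; on this read-out higher numbers stand for weaker inhibition and lower numbers for stronger inhibition. Among the compounds with values here, the single measured step, a 1.3-fold lower number from compound 1 to compound 2 (0.12 log units; within the scatter), lies within the scatter, so compound 2 and compound 1 cannot be set apart on these numbers; compound 2 is simply one of two closely matched entries in this short series. Compound 3 `COc1cc(Cl)c(Nc2nc(C#N)cn([C@@H](COCCF)C3CC3)c2=O)c(Cl)c1` differs from compound 2 in one place: cyano in place of bromo on an aromatic carbon. Within the data shown here, the only step that can be compared, a 1.3-fold lower number from compound 1 to compound 2 (0.12 log units; within the scatter), exchanged one halogen for another and left the number essentially unchanged; it gives no direct guidance on a cyano group, and no other measured pair covers this kind of change. The expectation is therefore a step near zero, a 1.5-fold higher number from compound 2 to compound 3 (0.18 log units; within the scatter), with a generous allowance for a group that has not been tested here. Compound 3 is estimated at 0.7 nM, in a range from 0.2 nM to 3 nM.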

Compound 3, half-maximal inhibitory concentration in the corticotropin-releasing factor receptor 1 assay: 7.7 nM
The estimate for compound 3 lay 11-fold (1.04 log units) below the measured number; the measured number lies above the stated range.
By their numbers in the corticotropin-releasing factor receptor 1 assay, from the lowest: compounds 2 and 1 (each within the scatter of the next); then compound 3.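

In the corticotropin-releasing factor receptor 1 assay, this position accepts an exchange of one halogen for another but not every replacement: cyano in place of bromo gives a 17-fold higher number from compound 2 to compound 3 (1.22 log units; beyond the scatter), and cyano in place of chloro gives a 13-fold higher number from compound 1 to compound 3 (1.11 log units; beyond the scatter). The near match between compounds 1 and 2 therefore did not mean that the carbon next to the ring nitrogen is indifferent to what it carries. The cyano-for-bromo change also shifts lipophilicity in a physicochemical assay for lipophilicity, using the shake flask method, in phosphate buffer, measured as octanol-water partition, with a stated time of 40 min, at pH 7.4; a lower number here means a more polar compound, a higher number a more lipophilic compound: the measured distribution coefficient of compound 2, 4.1, and of compound 3, 3.4, a number 0.70 log units lower (beyond the scatter) In the physicochemical assay compound 2 gives 4.1, and compound 3 gives 3.4.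

This single pair cannot show whether that drop in lipophilicity or some other difference between bromo and cyano accounts for the weaker inhibition of compound 3. A methyl group or an amine on this carbon would show whether other non-halogen groups also raise the number.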